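Double-bond geometry in a biphenyl amino acid series

This account rests on a few compounds, and the source may have more. Where it says the series, first, only, none or still open, it means among the compounds named here.

Measured compounds:
compound 1, `NC(C/C=C(\c1ccc(-c2ccccc2)cc1)c1ccc(F)cc1F)C(=O)O`: > 10000 nM
compound 2, `CCc1ccc(/C(=C\CC(N)C(=O)O)c2ccc(F)cc2F)cc1`: > 10000 nM

In a functional assay for inhibition of sodium- and chloride-dependent glycine transporter 1 (Rattus norvegicus), with a stated time of 30 min, in the presence of a further agent that is not named here (on this read-out lower numbers stand for stronger inhibition and higher numbers for weaker inhibition), compound 1 gives > 10000 nM, which is a limit of the assay and not a number. Compound 2 gives > 10000 nM, also a limit. Among the compounds with values here, the only measured step, a step that the two limits leave unreadable from compound 1 to compound 2, is thus unreadable; both values sit on (the limit of > 10000 nM in this assay, at which 2 of the 2 values shown sit), so compound 1 stands only at that limit and nothing shows how far beyond it either compound lies.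

Compound 3, `NC(C/C=C(/c1ccc(-c2ccccc2)cc1)c1ccc(F)cc1F)C(=O)O`, differs from compound 1 by the two compounds have the same atoms and bonds; at least one stereo element is drawn with a configuration in one of them and without one in the other: 1 of 2 stereo elements differ; a double bond is drawn E in compound 1 and Z in compound 3. Within the data shown here, no measured step concerns this change, and the one step that exists, from compound 1 to compound 2, gives no size at all. The expected step that the limit leaves unreadable from compound 1 to compound 3 is therefore without a basis beyond the limit itself, and no movement beyond the scatter is expected in either direction. Compound 3 is expected in this assay at 15000 nM, within 3000 nM to 60000 nM, most likely again reported as a limit.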

Compound 3, half-maximal inhibitory concentration: 3400 nM
For compound 3 the middle estimate is 4.4-fold (0.64 log units) above the measured one, and the stated range covers the measured number.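

In this assay, within the data shown here, reversing the geometry of the double bond while keeping every atom and bond gives the first readable step: an at least 2.9-fold lower number from compound 1 to compound 3 (0.46 log units; beyond the scatter). Among these compounds, compounds 1 and 2 showed only limits of the assay, so compound 3 is the first sign that the read-out responds to a change at this double bond. From the compounds shown here alone, the true size of the step stays unknown because compound 1 provides only a limit: the limit of > 10000 nM in this assay, at which 2 of the 3 values shown sit.

Going by these compounds, it remains open whether ethyl in place of phenyl would keep this level of inhibition with the double bond drawn as in compound 3, or whether a methyl ester in place of the carboxylic acid would do so. The reading of the geometry change also carries a reservation: the fact that one of compounds 1 and 3 is drawn with a defined configuration and the other without, at the place where they differ.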